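Working notes: methylcarbamoyl to carbamoyl from compound 2

The compounds below may be only part of what the source reports. "The series", "measured", "known", "first", "only" and "open" are said of these compounds alone.

Of the compounds shown here, three have numbers so far in a functional assay on NCI-H1975 cells (Homo sapiens) for antiproliferative activity, read by CCK-8 assay, with a stated time of 72 h; a lower number here means a stronger inhibitor of growth, a higher number a weaker inhibitor of growth. Compound 1 `CCC1C(=O)N(C)c2cnc(Nc3ccc(S(=O)(=O)NC)cc3)nc2N1c1ccn(C)n1` gives 18800 nM and compound 2 `CCC1C(=O)N(C)c2cnc(-n3ccc4cc(C(=O)NC)ccc43)nc2N1c1ccn(C)n1` gives 35700 nM, a pair that lies within the scatter of each other. Compound 3 `CCCNC(=O)c1ccc2c(ccn2-c2ncc3c(n2)N(C2CCCC2)[C@H](CC)C(=O)N3C)c1` gives 786 nM, a much lower number than compound 2 shows and a gap beyond the scatter. Compound 3 differs from compound 2 in more than one place, so that gap cannot be assigned to any single group.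

Compound 4 `CCC1C(=O)N(C)c2cnc(-n3ccc4cc(C(N)=O)ccc43)nc2N1c1ccn(C)n1` keeps the rest of compound 2 and changes only its amide: hydrogen in place of methyl on an amide-type nitrogen. This puts hydrogen in place of methyl on an amide-type nitrogen, turning methylcarbamoyl into carbamoyl. Among the measured compounds shown here, no measured pair isolates this change, so there is no direct precedent for it. For the measured compounds named here, the only anchor is compound 2 at 35700 nM in this assay. A small change is expected, with no move beyond the scatter in either direction. The expected step of a 1.2-fold lower number from compound 2 to compound 4 (0.08 log units; within the scatter) stays within that scatter. For compound 4 the estimated value is 30000 nM, with an expected range of 11000 nM to 70000 nM.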

Compound 4, concentration for 50% growth inhibition: "not active" (no number reported)
The entry for compound 4 holds no number, so the estimate cannot be set against anything.
By their numbers in this assay, from the lowest: compound 3; then compounds 1 and 2 (each within the scatter of the next).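

In this assay compound 4 is entered as not active with no number, so no step can be read between compound 2 and compound 4. Nothing measured here accounts for that entry. The compounds shown leave open how far methylcarbamoyl to carbamoyl moves growth inhibition on its own.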